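Trimming a tert-butyl group down to a methyl

This account rests on a few compounds, and the source may have more. Where it says the series, first, only, none or still open, it means among the compounds named here.

Compound 1 `O=C(Nc1ccc(F)cc1)c1ccnc2cc(Br)ccc12` gives > 20000 nM
Compound 2 `O=C(Nc1ccc(F)cc1F)c1cc(=O)[nH]c2cc(Br)ccc12` gives > 20000 nM
Compound 3 `CC(C)(C)c1ccc(-c2ccc3c(C(=O)Nc4cccc(F)c4)cc(=O)[nH]c3c2)cc1` gives > 20000 nM

These readings come from a functional assay on KYSE-70 cells for antiproliferative activity against KYSE-70 cell line (Homo sapiens), read by MTT assay, with a stated time of 72 h (a higher number here means a weaker inhibitor, a lower number a stronger inhibitor), and each one is a limit of the assay and not a number. All three compounds stand together: the limit of > 20000 nM in this assay, at which 3 of the 3 values shown sit. Compound 3 therefore has no exact value of its own, and its > 20000 nM is a limit.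

Compound 4 `Cc1ccc(-c2ccc3c(C(=O)Nc4cccc(F)c4)cc(=O)[nH]c3c2)cc1` keeps all of compound 3 except one group, with methyl in place of tert-butyl on an aromatic carbon, para to a large group. The change is 4-(tert-butyl)phenyl to 4-methylphenyl: methyl in place of tert-butyl on an aromatic carbon.

Going by the values given here, no measured pair here shows what such a swap does, and none of the three compounds has yet given a number. The expectation is therefore no change beyond the scatter, though a small gain in strength cannot be excluded. The expected step is a number no higher from compound 3 to compound 4 (the limit leaves the size open). For compound 4 the estimated value is 20000 nM, with an expected range of 8000 nM to 40000 nM.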

Compound 4, half-maximal inhibitory concentration: > 20000 nM
Compound 4 ended at the assay's limit (the forecaster's own chance of this, stated with the estimate: 65%); the middle value sits exactly at the limit.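

No step can be read from compound 3 to compound 4, as both readings are limits of the assay and not numbers. None of the compounds shown has an exact value, so what any single change does to strength stays open: the limit of > 20000 nM in this assay, at which 4 of the 4 values shown sit.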